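The compounds below may be only part of what the source reports. "The series", "measured", "known", "first", "only" and "open" are said of these compounds alone.

Three compounds have been measured in a functional assay (B cells) with Mus musculus as the target; on this read-out higher numbers stand for an effect only at larger amounts of compound and lower numbers for an effect already at smaller amounts:

Compound 1, `NCC(O)Cn1c(=O)n(C2OC(CO)[C@@H](O)[C@H]2O)c2nc(N)nc(O)c21`, gives 28 uM.
Compound 2, `C=CCn1/c(=N\C#N)n([C@H]2OC(CO)[C@@H](O)[C@H]2O)c2cc(N)nc(O)c21`, gives 156 uM.
Compound 3, `C=CCn1c(=O)n(Cc2ccccc2)c2nc(N)nc(O)c21`, gives 5 uM.

Among these three numbers compound 1 holds the second highest. The nearest to it is compound 2, whose value lies higher by a gap beyond the scatter; the furthest is compound 3, whose value lies lower by a gap of the same size, also beyond the scatter. Compound 4, `NC(=O)Cn1c(=O)n(C2OC(CO)[C@@H](O)[C@H]2O)c2nc(N)nc(O)c21`, has not yet been measured. It differs from compound 1 in one place: carbamoyl in place of 2-amino-1-hydroxyethyl on a saturated chain carbon bound to an aromatic nitrogen. For the measured compounds named here, no pair of measured compounds differs in exactly this way, and none of the three measured compounds carries the group that enters, so there is no measured step to lean on. The step from compound 1 to compound 4 is expected to be small, toward a somewhat higher number or none beyond the scatter, a 1.3-fold higher number from compound 1 to compound 4 (0.10 log units; within the scatter). On that basis compound 4 is estimated to give 35 uM in this assay, within a range from 10 uM to 120 uM.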

Compound 4, concentration for half-maximal effect: 190 uM
Estimate against measurement, compound 4: 5.4-fold (0.73 log units) below, and the stated range ends below it.
By their numbers in this assay, from the lowest: compound 3; then compound 1; then compounds 2 and 4 (each within the scatter of the next).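

Replacing 2-amino-1-hydroxyethyl with carbamoyl on a saturated chain carbon bound to an aromatic nitrogen leads in this assay to a 6.8-fold higher number from compound 1 to compound 4 (0.83 log units; beyond the scatter) and shows that this read-out is sensitive to the group at this place. The step is large even though the two groups are close in size, with 4 and 3 heavy atoms and no net charge on either, so a count of atoms says little about the outcome here. Nothing available explains the step.

A single pair cannot tell whether the loss of the amine, the loss of the hydroxyl or the arrival of the carbonyl matters most. Neither 3-aminopropyl, which keeps the amine without the hydroxyl, nor a carboxylic acid such as carboxymethyl appears among these compounds, so their effect at this place remains open.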